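The compounds below may be only part of what the source reports. "The series", "measured", "known", "first", "only" and "open" are said of these compounds alone.

Values measured in an ADME assay on liver for metabolic stability, with Liver microsome (Homo sapiens) as the target, read by LC-MS, using microsomes, with a stated time of 5 h; a lower number here means slower removal, a higher number faster removal of the compound:

- Compound 1 `OC(c1ccccn1)C1(c2ccc(Cl)c(Cl)c2)CCOC1` gives 417 mL/min/kg
- Compound 2 `C[C@]1(c2ccc(OC(F)(F)F)cc2)C[C@@](O)(c2ccccn2)CO1` gives 117 mL/min/kg
- Compound 3 `C[C@]1(O)C[C@](c2ccnc(C(F)(F)F)c2)([C@H](O)c2ccccn2)C1` gives 66.7 mL/min/kg

Among these three compounds, compound 2 stands well under compound 1, and the gap between them lies beyond the usual scatter. Compound 2 and compound 3 lie within the scatter of each other, so their two values cannot be ranked. The next compound to be tested, compound 4 `C[C@@]1(c2ccc(OC(F)(F)F)cc2)C[C@@](O)(c2ccccn2)CO1`, has the same atoms and bonds as compound 2. The change is the two compounds have the same atoms and bonds and differ only in configuration as drawn: 1 of 2 stereo elements differ; a stereocentre at a saturated ring carbon is drawn R in compound 2 and S in compound 4, so a stereocentre at a saturated ring carbon is drawn R in compound 2 and S in compound 4.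

The measured compounds offer no pair that differs in one place, so the size of a change in configuration in this assay has not been shown in this series. The best available anchor is compound 2 at 117 mL/min/kg, and there is no evidence for a direction of change. The expected result is a 1.1-fold lower number from compound 2 to compound 4 (0.03 log units; within the scatter), a step estimated to stay within the scatter. The estimated value for compound 4 is 110 mL/min/kg, with an expected range of 50 mL/min/kg to 240 mL/min/kg.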

Compound 4, clearance: 66.7 mL/min/kg
Compound 4: middle estimate off by 1.6-fold (0.22 log units), on the high side, and the stated range covers the measured number.
By their numbers in this assay, from the lowest: compounds 3, 4 and 2 (each within the scatter of the next); then compound 1.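

With this result the series gains its first pair that differs in one place, so the size of a change in configuration in this assay can now be read directly, and the step is a 1.8-fold lower number from compound 2 to compound 4 (0.24 log units; within the scatter). At this saturated ring carbon, then, drawing the stereocentre R or S does not separate the two compounds, and this single pair gives no ground for ranking one form above the other. The earlier compounds shown here could not speak to this, since they differ from one another in several places at once, whereas here the comparison rests on configuration alone: the fact that compounds 2 and 4 differ only in the configuration as drawn.

Still open, on these data alone, is whether the second stereocentre, drawn alike in both compounds, would give a step beyond the scatter if it were inverted, and whether the same small step would hold for the other inversions of this pair on a different aryl group. Also open, as far as these compounds go, is what an amine or a carboxylic acid on the shared core would do to the number in this assay.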